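This account rests on a few compounds, and the source may have more. Where it says the series, first, only, none or still open, it means among the compounds named here.

Working notes on the series built around compound 1 `C/C(=N\NC(=O)c1cccc(S(=O)(=O)N2CCOCC2)c1)c1cccc(N)c1O` and compound 2 `O=C(N/N=C/c1ccccn1)c1cccc(S(=O)(=O)N2CCOCC2)c1`, which share a core and differ in the aryl group on the hydrazone carbon. In a functional assay on SMMC-7721 cells (Homo sapiens) for antiproliferative activity, read by MTT assay, with a stated time of 72 h (a higher number here means a weaker inhibitor, a lower number a stronger inhibitor), compound 1 gives 2330 nM. On these data alone, compound 2 reaches only a limit, > 100000 nM, so its true place on the scale is unknown; this is the limit of > 100000 nM in this assay, at which 1 of the 2 values shown sits. Compound 3 `CCOc1cccc(/C=N/NC(=O)c2cccc(S(=O)(=O)N3CCOCC3)c2)c1O` carries 3-ethoxy-2-hydroxyphenyl in place of pyridin-2-yl on a carbon with a double bond to nitrogen. Among the measured compounds shown here, no measured step covers this change, so the direction rests on compound 1 alone, which gives a measurable number. A gain in this assay is expected for compound 3, estimated at 6000 nM with a range of 1500 nM to 40000 nM. The expected step is an at least 16-fold lower number from compound 2 to compound 3 (1.22 log units; beyond the scatter), a gain well beyond the scatter.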

Compound 3, half-maximal inhibitory concentration: 6990 nM
Compound 3: the middle estimate sits 1.2-fold (0.07 log units) below what was measured; low and high end bracket the measured number.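

The aryl group on the carbon with a double bond to nitrogen now has its first single-place step in this assay: 3-ethoxy-2-hydroxyphenyl in place of pyridin-2-yl gives an at least 14-fold lower number from compound 2 to compound 3 (1.15 log units; beyond the scatter). This shows that the change at this position alone is enough to bring the shared core to a measurable number. The true size of the step stays unknown because compound 2 stands only at a limit: the limit of > 100000 nM in this assay, at which 1 of the 3 values shown sits.

The compounds shown leave open whether the gain follows the hydroxy group, the ethoxy group or both. On these data alone, how a propoxy chain or an amine in place of the ethoxy group would read also remains open.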